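Swapping tert-butyl for benzyl on a shared core

The source may report more compounds than this note shows. Statements on the series, on what has been measured and on what is new or still open speak of the compounds shown alone.

Compound 1 `COC(=O)CCC(NC(=O)[C@@H]1CCC(=O)N1)C(=O)N1CCC[C@H]1C(N)=O`: 0.333 h
Compound 2 `NC(=O)[C@@H]1CCCN1C(=O)C(CCC(=O)OC1CCCCC1)NC(=O)[C@@H]1CCC(=O)N1`: 0.417 h
Compound 3 `CC(C)(C)OC(=O)CCC(NC(=O)[C@@H]1CCC(=O)N1)C(=O)N1CCC[C@H]1C(N)=O`: 1.17 h

In an ADME assay on the whole organism (brain) for pharmacokinetics, with Mus musculus as the target (on this read-out higher numbers stand for a longer-lived compound and lower numbers for a shorter-lived compound), compound 3 has the highest of the three numbers. Compound 4 `NC(=O)[C@@H]1CCCN1C(=O)C(CCC(=O)OCc1ccccc1)NC(=O)[C@@H]1CCC(=O)N1` is not yet measured. It carries benzyl in place of tert-butyl on an oxygen next to a carbonyl group. Two modest measured steps bear on this swap, a 3.5-fold higher number from compound 1 to compound 3 (0.55 log units; beyond the scatter) and a 2.8-fold higher number from compound 2 to compound 3 (0.45 log units; beyond the scatter), each beyond the scatter. By contrast, a 1.3-fold higher number from compound 1 to compound 2 (0.10 log units; within the scatter) stays within it. Three compounds are a thin basis, and none carries benzyl, but a drop of similar size seems likely. The expected change is a 2.6-fold lower number from compound 3 to compound 4 (0.41 log units; beyond the scatter). Compound 4 is estimated at 0.45 h, within an expected range of 0.22 h to 1 h.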

Compound 4, half-life: > 2 h
Compound 4: only a limit was reported (the forecaster's own chance of this, stated with the estimate: 2%); middle value at least 4.4-fold (0.64 log units) from the limit.
By their numbers in this assay, from the lowest: compounds 1 and 2 (each within the scatter of the next); then compound 3. At a limit, above all of these: compound 4.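

In this assay compound 4 gives > 2 h, which is a limit of the assay and not a number. With benzyl on this oxygen next to a carbonyl group, the read-out rises clear of both cyclohexyl and methyl, with an at least 4.7-fold higher number from compound 2 to compound 4 (0.68 log units; beyond the scatter) and an at least 6.0-fold higher number from compound 1 to compound 4 (0.77 log units; beyond the scatter). Against tert-butyl the gain is unsettled, with an at least 1.7-fold higher number from compound 3 to compound 4 (0.23 log units; that floor lies within the scatter), so benzyl matches or passes that group here.

From the compounds shown here alone, the true half-life of compound 4 remains open. So does whether phenyl or a longer phenylethyl chain on this oxygen would give a similar result.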